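Chloro in Place of Methyl on the Sulfonyl Phenyl

A few compounds are considered here, and "the series" means these few. Any claim that something is new, unique, unknown or untested is made for them only; others in the source may bear on it.

Compound 1 `Cc1ccc(S(=O)(=O)Nc2cccc(-c3ccc(C(=O)c4cc(F)c(F)c(O)c4F)s3)c2)cc1` gives 0.2 nM in an assay on microsomes from placenta for inhibition of 17-beta-hydroxysteroid dehydrogenase type 2 (Homo sapiens), read by HPLC, in the presence of a further agent that is not named here; a lower number here means a stronger inhibitor, a higher number a weaker inhibitor. Compound 2 `Cc1cccc(S(=O)(=O)Nc2cccc(-c3ccc(C(=O)c4cc(F)c(F)c(O)c4F)s3)c2)c1` gives 0.2 nM in this assay, and the step of no change at the digits printed from compound 1 to compound 2 (within the scatter) is within the scatter, so compound 2 stands level with compound 1. Compound 3 `O=C(c1ccc(-c2cccc(NS(=O)(=O)c3cccc(Cl)c3)c2)s1)c1cc(F)c(F)c(O)c1F` differs from compound 2 by chloro in place of methyl on an aromatic carbon. Among the measured compounds shown here, the only measured step, no change at the digits printed from compound 1 to compound 2 (within the scatter), concerns a different exchange on the same 3-methylphenyl group and bears on this change only loosely; no methyl-to-chloro step has been measured. For compound 3 a step of no more than the scatter is expected, a 1.5-fold higher number from compound 2 to compound 3 (0.18 log units; within the scatter). Compound 3 is therefore estimated at 0.3 nM, with a range from 0.1 nM to 0.9 nM.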

Compound 3, half-maximal inhibitory concentration: 0.4 nM
Beside the measured number, compound 3's estimate is 1.3-fold (0.12 log units) below it; low and high end bracket the measured number.
By their numbers in this assay, from the lowest: compounds 1, 2 and 3 (each within the scatter of the next).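

Going from 3-methylphenyl to 3-chlorophenyl on the sulfonyl sulfur gives a 2.0-fold higher number from compound 2 to compound 3 (0.30 log units; within the scatter), so in this assay this position accepts chloro as well as methyl without a step beyond the scatter. Read from the 4-methylphenyl group, the exchange gives a 2.0-fold higher number from compound 1 to compound 3 (0.30 log units; within the scatter), which also keeps compound 3 level with compound 1. Nothing available gives a reason for this result.

Going by these compounds, whether an amine, a carboxylic acid or a methoxy group on this phenyl ring would stay in the same range remains open. So does whether a 4-chlorophenyl group would match the 3-chlorophenyl group.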